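Iodo for methoxy on the aryl amine of the acylguanidine series

The compounds below may be only part of what the source reports. "The series", "measured", "known", "first", "only" and "open" are said of these compounds alone.

Measured so far:
compound 1, `COc1ccc(N/C(=N\C(=O)c2ccccc2)NCc2ccccc2)cc1`, 837000 nM
compound 2, `O=C(/N=C(/NCc1ccccc1)Nc1ccc(Br)cc1)c1ccccc1`, 738000 nM

Two compounds carry a number in an ADME assay on cells (Peritoneal macrophage, Mus musculus) for cytotoxicity, read by MTT assay, with a stated time of 24 h; on this read-out lower numbers stand for higher toxicity in this test and higher numbers for lower toxicity in this test. Compound 1 gives 837000 nM and compound 2 gives 738000 nM; the two lie within the scatter of one another, so compound 1 stands level with compound 2 and neither can be called more or less toxic on this evidence. Going by the values given here, the one measured step, a 1.1-fold lower number from compound 1 to compound 2 (0.05 log units; within the scatter), tells that swapping the methoxy for a halogen on that aromatic carbon left the read-out unchanged within the scatter.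

The next compound, compound 3 `O=C(/N=C(/NCc1ccccc1)Nc1ccc(I)cc1)c1ccccc1`, has not yet been measured. It differs from compound 1 as follows: iodo in place of methoxy on an aromatic carbon. Among the compounds with values here, the single step that bears on this is the one from compound 1 to compound 2, a halogen for the same methoxy at the same place, and it was within the scatter. The expectation for compound 3 is therefore no step beyond the scatter in this assay, and the estimated change a 1.1-fold lower number from compound 1 to compound 3 (0.05 log units; within the scatter) reflects that. Compound 3 is expected to give about 750000 nM, within a range of 350000 nM to 1600000 nM.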

Compound 3, half-maximal cytotoxic concentration: 619000 nM
Compound 3: middle estimate off by 1.2-fold (0.08 log units), on the high side; low and high end bracket the measured number.
By their numbers in this assay, from the lowest: compounds 3, 2 and 1 (each within the scatter of the next).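

Working in this assay, iodo in place of methoxy on this aromatic carbon, para to a large group, gives a 1.4-fold lower number from compound 1 to compound 3 (0.13 log units; within the scatter) and so adds a second halogen that stands level with the methoxy compound. The exchange between the two halogens gives a 1.2-fold lower number from compound 2 to compound 3 (0.08 log units; within the scatter) and shows that iodo and bromo cannot be told apart here, which leaves all three substituents at this position level in this assay on the present numbers. Nothing at hand accounts for this lack of a readable difference among methoxy, bromo and iodo at this place.

Methoxy, bromo and iodo are the only groups shown on this aromatic carbon, so it remains open whether an amine, a carboxylic acid or a longer chain there would also stay within the scatter of compound 1. The rest of the shared core is the same in compound 1, compound 2 and compound 3, so these numbers say nothing about how a change elsewhere in the core would read in this assay or whether this position would behave the same way alongside it.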